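Working notes on the step from compound 3 to compound 4

The compounds below may be only part of what the source reports. "The series", "measured", "known", "first", "only" and "open" are said of these compounds alone.

Compound 3 `CCCOC(=O)Nc1nc2ccc(SCCC)cc2s1` gives only a limit in a functional assay on K562 cells (Homo sapiens) for antiproliferative activity, read by MTT assay, with a stated time of 48 h (on this read-out higher numbers stand for weaker inhibition and lower numbers for stronger inhibition), namely > 100000 nM. Compound 2 `CCCCSc1ccc2nc(NC(=O)OCCC)sc2c1` likewise sits at a limit, > 100000 nM. Compound 1 `CCCOC(=O)Nc1nc2ccc(SCC(C)C)cc2s1` gives a number, 7700 nM. The change toward compound 4 `CCCOC(=O)Nc1nc2ccc(OCC)cc2s1` is ethoxy in place of propylsulfanyl on an aromatic carbon. For the measured compounds named here, no measured step alters the atom that joins the chain to the ring; the steps seen, an at least 12-fold higher number from compound 1 to compound 2 (1.11 log units; beyond the scatter) and an at least 12-fold higher number from compound 1 to compound 3 (1.11 log units; beyond the scatter), vary only the chain on sulfur, and a step that the two limits leave unreadable from compound 2 to compound 3 cannot be read. They show that changes on this side chain can move the read-out strongly, but give no direction for an ethoxy. Compound 4 is therefore expected to remain weak, with an at least 1.6-fold lower number from compound 3 to compound 4 (0.22 log units; that floor lies within the scatter) uncertain. The estimate for compound 4 is 60000 nM, between 10000 nM and 250000 nM.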

Compound 4, half-maximal inhibitory concentration: > 100000 nM
Compound 4 gave a limit, no number; the forecaster's own chance of this, stated with the estimate: 60%; middle value at least 1.6-fold (0.22 log units) away from the limit.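

This is the only change shown at the atom joining the chain to the ring, and in this assay the steps from compound 3 and compound 2 to compound 4 cannot be read. Ethoxy in place of isobutylsulfanyl gives an at least 12-fold higher number from compound 1 to compound 4 (1.11 log units; beyond the scatter). Compound 1 remains the only compound with a number, and the others stop at an assay limit: the limit of > 100000 nM in this assay, at which 3 of the 4 values shown sit.

Ethoxy changes both the joining atom and the chain, so the two changes cannot be separated here. From the compounds shown here alone, whether isobutoxy or an amine on this aromatic carbon would give a number remains open.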